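This account rests on a few compounds, and the source may have more. Where it says the series, first, only, none or still open, it means among the compounds named here.

Measured so far in a functional assay on HeLa cells (Homo sapiens) for cytotoxicity, read by CCK-8 assay, with a stated time of 72 h; on this read-out lower numbers stand for stronger inhibition and higher numbers for weaker inhibition:
- compound 1, `C=CCn1c(=O)/c(=C\c2cccc(C)c2)[nH]c(=O)/c1=C\c1ccccc1OC`: 19300 nM
- compound 2, `C=CCn1c(=O)/c(=C\c2ccc(Cl)c(Cl)c2)[nH]c(=O)/c1=C\c1ccccc1`: "not active" (no number reported) (no number was obtained for compound 2)
- compound 3, `C=CCn1c(=O)/c(=C\c2cccc(F)c2)[nH]c(=O)/c1=C\c1ccccc1OC`: 9100 nM

Compound 3 holds the lowest of the two numbers in this assay; the nearest neighbour is compound 1, and the step of a 2.1-fold lower number from compound 1 to compound 3 (0.33 log units; beyond the scatter) lies beyond the scatter, though it is modest. Compound 2 gave no number at all, and since it differs from compound 3 in more than one place it offers no single-point comparison.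

Compound 4, `C=CCn1c(=O)/c(=C\c2cc(F)ccc2C)[nH]c(=O)/c1=C\c1ccccc1OC`, differs from compound 3 by methyl in place of hydrogen on an aromatic carbon. For the measured compounds named here, no measured step adds a methyl to an otherwise unchanged ring, so the only related observation is the step from compound 1 to compound 3, which exchanged one small aromatic substituent for another and moved the number only modestly. By analogy, the change to compound 4 is expected to produce a step in this assay of about a 1.0-fold higher number from compound 3 to compound 4 (0.02 log units; within the scatter), that is, a number close to that of compound 3 and not clearly beyond the scatter in either direction. Compound 4 is therefore estimated at 9500 nM, with a range of 4000 nM to 25000 nM.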

Compound 4, half-maximal inhibitory concentration: 2900 nM
Beside the measured number, compound 4's estimate is 3.3-fold (0.52 log units) above it; measured number below the stated range.
By their numbers in this assay, from the lowest: compound 4; then compound 3; then compound 1.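

In this assay, for the compounds shown here, the methyl group, placed on an aromatic carbon ortho to a large group and para to a fluoro group, gives a 3.1-fold lower number from compound 3 to compound 4 (0.50 log units; beyond the scatter) and thus lies beyond the scatter; this is the only step here that adds a group to an otherwise unchanged ring, so this position responds to a substituent where hydrogen stood before. Replacing 3-methylphenyl with 5-fluoro-2-methylphenyl gives a 6.7-fold lower number from compound 1 to compound 4 (0.82 log units; beyond the scatter) and leaves compound 4 with the lowest of the three numbers, which shows that the fluoro and methyl groups can share this ring without a loss in this assay. The compounds shown include no measurement that accounts for either step.

Going by these compounds, it remains open whether the methyl group would give a similar step on a ring without the fluoro group, and whether ethyl or an amine at the same place would lower the number further. Compound 2 gave no number and differs from the others in more than one place, so the effect of its two chloro groups cannot be read.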